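Urea tail changes on the shared core: compound 4

A few compounds are considered here, and "the series" means these few. Any claim that something is new, unique, unknown or untested is made for them only; others in the source may bear on it.

Three ureas carry the same core and differ only in the group on the carbonyl carbon. Compound 1 `CN(C)CCNC(=O)Nc1cc2c(Nc3ccc(F)c(Cl)c3)ncnc2cc1O[C@H]1CCOC1` gives 806 nM in a functional assay on A-431 cells (Homo sapiens) for antiproliferative activity, read by sulforhodamine B assay, with a stated time of 72 h; a lower number here means a stronger inhibitor, a higher number a weaker inhibitor. Compound 2 `O=C(NCCN1CCCC1)Nc1cc2c(Nc3ccc(F)c(Cl)c3)ncnc2cc1O[C@H]1CCOC1` gives 247 nM in this assay, and compound 3 `CN(C)CCN(C)C(=O)Nc1cc2c(Nc3ccc(F)c(Cl)c3)ncnc2cc1O[C@H]1CCOC1` gives 450 nM. Compound 2 holds the lowest number of the three: the step of a 1.8-fold higher number from compound 2 to compound 3 (0.26 log units; within the scatter) sits within the scatter, the step of a 1.8-fold lower number from compound 1 to compound 3 (0.25 log units; within the scatter) likewise, whereas the step of a 3.3-fold lower number from compound 1 to compound 2 (0.51 log units; beyond the scatter) lies beyond it.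

Compound 4 `O=C(Nc1cc2c(Nc3ccc(F)c(Cl)c3)ncnc2cc1O[C@H]1CCOC1)N1CC(O)C1` is not yet measured. Relative to compound 2 the change is 3-hydroxyazetidin-1-yl in place of (2-(pyrrolidin-1-yl)ethyl)amino on a carbonyl carbon. Among the measured compounds shown here, no measured step exchanges the whole (2-(pyrrolidin-1-yl)ethyl)amino group; the closest precedent is a 3.3-fold lower number from compound 1 to compound 2 (0.51 log units; beyond the scatter), where pyrrolidin-1-yl in place of dimethylamino moved the number beyond the scatter, while a 1.8-fold higher number from compound 2 to compound 3 (0.26 log units; within the scatter) and a 1.8-fold lower number from compound 1 to compound 3 (0.25 log units; within the scatter) show that a methyl on the amide-type nitrogen stays within it. A change of this extent is expected to move the number, more likely upward, by a 2.8-fold higher number from compound 2 to compound 4 (0.45 log units; beyond the scatter). Compound 4 is therefore estimated at 700 nM in this assay, with a range of 200 nM to 2500 nM.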

Compound 4, half-maximal inhibitory concentration: 1930 nM
The estimate for compound 4 lay 2.8-fold (0.44 log units) below the measured number, and the stated range covers the measured number.
By their numbers in this assay, from the lowest: compounds 2, 3 and 1 (each within the scatter of the next, the first and the last beyond it); then compound 4.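

Among the compounds shown here, exchanging the whole group on the carbonyl carbon for 3-hydroxyazetidin-1-yl, where the earlier steps altered only part of it, raises the number in this assay against all three earlier ureas: a 7.8-fold higher number from compound 2 to compound 4 (0.89 log units; beyond the scatter), a 4.3-fold higher number from compound 3 to compound 4 (0.63 log units; beyond the scatter) and a 2.4-fold higher number from compound 1 to compound 4 (0.38 log units; beyond the scatter). For the compounds shown here, compound 4 therefore stands beyond the scatter from every other compound, so a replacement of this extent at the position registers against each earlier urea, whereas the earlier compounds included pairs within the scatter. The entering group has one nitrogen and one oxygen where the leaving group has two nitrogens, but nothing available explains the rise.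

The compounds shown leave open whether the four-membered ring, the hydroxyl or the loss of the chain carries the change. A 3-(dimethylamino)azetidin-1-yl group on the carbonyl carbon, keeping the ring and restoring an amine, would help separate these.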